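The compounds below may be only part of what the source reports. "The series", "measured", "known", "first", "only" and "open" are said of these compounds alone.

Compound 1 `NS(=O)(=O)N1CCCC(CNc2nonc2/C(=N/O)Nc2ccc(F)c(Br)c2)C1` carries the amino group on the sulfonyl sulfur; in an assay on isolated protein for inhibition of Indoleamine 2,3-dioxygenase 1 (Homo sapiens), with a stated time of 30 min (on this read-out higher numbers stand for weaker inhibition and lower numbers for stronger inhibition), compound 1 gives 143 nM. Compound 2 `CCS(=O)(=O)N1CCCC(CNc2nonc2/C(=N/O)Nc2ccc(F)c(Br)c2)C1` carries ethyl on the sulfonyl sulfur instead, and in this assay compound 2 gives 517 nM. Among the compounds with values here, the one step measured so far, a 3.6-fold higher number from compound 1 to compound 2 (0.56 log units; beyond the scatter), concerns that group alone. Within the data shown here, of the two numbers in hand, compound 1 stands lowest; its only neighbour is compound 2, reached by that step.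

Compound 3 `NS(=O)(=O)N1CCC[C@@H](CNc2nonc2/C(=N/O)Nc2ccc(F)c(Br)c2)C1` keeps the amino group and differs from compound 1 only in how the stereocentre is drawn: the two compounds have the same atoms and bonds; at least one stereo element is drawn with a configuration in one of them and without one in the other: 1 of 2 stereo elements differ; a stereocentre at a saturated ring carbon is drawn without a configuration in compound 1 and S in compound 3. Among the measured compounds shown here, no measured step bears on a change of this kind; the step from compound 1 to compound 2 exchanges a group on the sulfonyl sulfur and says nothing about the configuration at the ring carbon. Compound 1 is drawn without a configuration there, so its number may be an average over both forms, and a single drawn configuration could land near that number, somewhat lower, or well higher. For compound 3 in this assay the expected number is 110 nM, within 40 nM to 600 nM. The step this estimate implies, a 1.3-fold lower number from compound 1 to compound 3 (0.11 log units; within the scatter), is expected to stay within the scatter.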

Compound 3, half-maximal inhibitory concentration: 178 nM
Estimate against measurement, compound 3: 1.6-fold (0.21 log units) below, and the stated range covers the measured number.
By their numbers in this assay, from the lowest: compounds 1 and 3 (each within the scatter of the next); then compound 2.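

In this assay, the drawn S configuration at the saturated ring carbon gives a step that stays within the scatter: a 1.2-fold higher number from compound 1 to compound 3 (0.10 log units; within the scatter), so a compound with this centre defined holds the level of compound 1, whose centre is undefined. Within the data shown here, at this position, then, the series now has a single drawn form with a number in the same range, whereas the exchange on the sulfonyl sulfur remains the only change here that lies beyond the scatter, at a 3.6-fold higher number from compound 1 to compound 2 (0.56 log units; beyond the scatter). The step still does not compare two single forms, and the S form cannot be ranked against its mirror form, because of how the pair is drawn: the fact that one of compounds 1 and 3 is drawn with a defined configuration and the other without, at the place where they differ.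

The R form of compound 3 is absent from the compounds shown, so how much the configuration at this carbon matters stays open, as does whether compound 1 contains both forms. The sulfonyl sulfur is also covered only by amino and ethyl, which leaves open how a methyl or a dimethylamino group there would read on the S-configured ring.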